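A few compounds are considered here, and "the series" means these few. Any claim that something is new, unique, unknown or untested is made for them only; others in the source may bear on it.

Measured in an ADME assay on HepG2 cells (Homo sapiens) for cytotoxicity, read by MTT assay, with a stated time of 24 h; a lower number here means that less compound is tolerated, a higher number that more compound is tolerated:
compound 1 `CC(C)=CCC1=C(OCc2cn(C3CCNCC3)nn2)C(=O)c2ccccc2C1=O` gives 570000 nM
compound 2 `CC(C)=CCC1=C(OCc2cn(Cc3ccccn3)nn2)C(=O)c2ccccc2C1=O` gives 658000 nM
compound 3 `CC(C)=CCC1=C(OCc2cn(-c3ccc(S(N)(=O)=O)cc3)nn2)C(=O)c2ccccc2C1=O` gives 483000 nM

Compound 3 carries the lowest of the three numbers on paper, yet both of its steps to the others stay within the scatter: a 1.2-fold lower number from compound 1 to compound 3 (0.07 log units; within the scatter) and a 1.4-fold lower number from compound 2 to compound 3 (0.13 log units; within the scatter). The remaining step, a 1.2-fold higher number from compound 1 to compound 2 (0.06 log units; within the scatter), is within the scatter as well. All three compounds share the same core and vary only the group on the aromatic nitrogen, and none of these swaps moved the number beyond the scatter in this assay.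

Compound 4 `CC(C)=CCC1=C(OCc2cn(-c3ccccc3C)nn2)C(=O)c2ccccc2C1=O` differs from compound 3 by 2-methylphenyl in place of 4-sulfamoylphenyl on an aromatic nitrogen. Within the data shown here, no measured step involves 2-methylphenyl, so no step bears directly on this change. Among the measured compounds shown here, the three steps that exist all exchange the group at this same position and all stay within the scatter, which is the only guide available. On that basis the step of a 1.1-fold higher number from compound 3 to compound 4 (0.03 log units; within the scatter) is expected to stay within the scatter, with no direction claimed. Compound 4 is therefore estimated at 520000 nM in this assay, with a range from 260000 nM to 1040000 nM.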

Compound 4, half-maximal cytotoxic concentration: 256000 nM
Compound 4: middle estimate off by 2.0-fold (0.31 log units), on the high side; the whole stated range lies above it.
By their numbers in this assay, from the lowest: compounds 4, 3, 1 and 2 (each within the scatter of the next, the first and the last beyond it).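

In this assay, among these compounds, the group on the aromatic nitrogen now shows that it can move the number: a 2.6-fold lower number from compound 2 to compound 4 (0.41 log units; beyond the scatter) and a 2.2-fold lower number from compound 1 to compound 4 (0.35 log units; beyond the scatter) are the first steps at this position to lie beyond the scatter, both modest and both on exchange for 2-methylphenyl. The separation is incomplete, since a 1.9-fold lower number from compound 3 to compound 4 (0.28 log units; within the scatter) stays within the scatter, so 2-methylphenyl cannot be told apart from 4-sulfamoylphenyl here, even though the two differ in size and in their hydrogen-bond donors and acceptors; compound 3 goes against any reading that sets 2-methylphenyl apart from all the other groups. Nothing in hand explains the shift.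

On these data alone, whether the lower number of compound 4 belongs to the methyl group or to the phenyl ring joined directly to the nitrogen stays open, as the steps from compound 1 and compound 2 change more than that one feature. Plain phenyl, 3-methylphenyl and 4-methylphenyl would bear on this, while a carboxylic acid or a longer alkyl chain at the same nitrogen would show how far the number can travel at this position.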